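Aryl vinyl sulfide ketone series: loss of the phenol

The source may report more compounds than this note shows. Statements on the series, on what has been measured and on what is new or still open speak of the compounds shown alone.

Measured so far:
compound 1 `Cc1ccc(CS/C(=C/c2ccc(C)s2)C(=O)c2ccc(Cl)cc2)cc1` 50000 nM
compound 2 `COc1cc(/C=C(/Sc2ccc(Br)cc2)C(=O)c2ccc(Br)cc2)ccc1O` 1000 nM

In a functional assay on DU-145 cells (Homo sapiens) for inhibition, read by trypan blue exclusion, with a stated time of 96 h (a lower number here means a stronger inhibitor of growth, a higher number a weaker inhibitor of growth), compound 2 gives 1000 nM, the lowest of the two numbers; compound 1 gives 50000 nM, a much higher number, beyond the scatter. Two compounds only, differing in several places at once, so no single change can be tied to that gap.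

Compound 3 `O=C(/C(=C\c1ccc(Br)cc1)Sc1ccc(Br)cc1)c1ccc(Br)cc1` is not yet measured. It differs from compound 2 in one place: 4-bromophenyl in place of 4-hydroxy-3-methoxyphenyl on a double-bonded chain carbon bound to a double-bonded chain carbon. The hydrogen-bond donor and one of the acceptors of compound 2 are gone from that ring.

Among the measured compounds shown here, with no measured pair that isolates this change, the expectation leans on compound 2 being the stronger of the two known compounds and on the phenol carrying the only donor in it. A step toward a higher number is expected, beyond the scatter, of about a 5.0-fold higher number from compound 2 to compound 3 (0.70 log units; beyond the scatter). Compound 3 is estimated at 5000 nM, in the range 1000 nM to 30000 nM.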

Compound 3, concentration for 50% growth inhibition: 1000 nM
For compound 3 the middle estimate is 5.0-fold (0.70 log units) above the measured one; measured number inside the range.
By their numbers in this assay, from the lowest: compounds 2 and 3 (each within the scatter of the next); then compound 1.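

In this assay, 4-bromophenyl in place of 4-hydroxy-3-methoxyphenyl on a double-bonded chain carbon bound to a double-bonded chain carbon gives no change at the digits printed from compound 2 to compound 3 (within the scatter). Among the compounds shown here, this is the first single-place comparison, and it shows that this position accepts a group with 0 hydrogen-bond donors and 0 hydrogen-bond acceptors with no loss in this read-out, so the phenol of compound 2 is not needed to hold the number here. Nothing measured beyond growth inhibition bears on why the two groups match.

Open, from the compounds shown here alone, is whether a ring carrying an amine or a carboxylic acid at this position would match compound 3, or whether the number would move. The gap to compound 1 also remains untied to any single change, since that compound differs from the others in several places.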